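Swapping the Acid Tail of Compound 2 for Cyclopentyl

A few compounds are considered here, and "the series" means these few. Any claim that something is new, unique, unknown or untested is made for them only; others in the source may bear on it.

Of the compounds shown here, three sharing one core have been tested in an assay on CHO cells for displacement of a labelled ligand from adenosine receptor A1 (Homo sapiens), read by scintillation counting, with a stated time of 60 min, tested at 10 uM; on this read-out lower numbers stand for less inhibition and higher numbers for more inhibition at the one concentration tested (going by the name of the read-out). Compound 1 `COc1cccc2cc(C(=O)NCC(=O)O)c(=O)oc12` gives 27%, while compound 2 `O=C(O)CNC(=O)c1cc2ccccc2oc1=O` gives 1%, and compound 3 `CCC(CO)NC(=O)c1cc2cc(Br)ccc2oc1=N` gives 20%. Compound 2 therefore stands lowest of the three numbers, with compound 3 nearest and compound 1 furthest from it, both differences lying beyond the usual scatter. Going by the values given here, the only single-place step measured so far is a number 26 percentage points lower from compound 1 to compound 2 (beyond the scatter), which arises from putting hydrogen in place of methoxy on an aromatic carbon.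

Compound 4 `O=C(NC1CCCC1)c1cc2ccccc2oc1=O` is not yet measured. It differs from compound 2 in a single place: cyclopentyl in place of carboxymethyl on an amide-type nitrogen. Among the compounds with values here, no measured step bears on this kind of change, since the one step on record alters an aromatic substituent rather than the group on the amide-type nitrogen, and compound 3 differs from compound 2 in several places at once, so its value can only be compared directly. With no guide from the data, the expectation for compound 4 is a small rise of uncertain size, a number 14 percentage points higher from compound 2 to compound 4 (beyond the scatter), and compound 4 is estimated at 15%, within a range from -5% to 45%.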

Compound 4, a percentage reported as inhibition, at one concentration (the size of the read-out at that concentration, not a potency): 16%
The estimate for compound 4 lay 1 percentage points below the measured number, within the range that was stated.
By their numbers in this assay, from the lowest: compound 2; then compounds 4, 3 and 1 (each within the scatter of the next, the first and the last beyond it).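

Going by these compounds alone, the one earlier step changed an aromatic substituent, so this is the first view of the group on the amide-type nitrogen changed on its own. In this assay, putting cyclopentyl in place of carboxymethyl gives a number 15 percentage points higher from compound 2 to compound 4 (beyond the scatter), which shows that this place affects the read-out and that a ring of carbon only can stand there without the number falling. The step is modest and comes from a single pair of compounds at one concentration, and no supporting measurement is available to explain why the number rises.

This single swap removes the carboxylic acid and brings in the ring at the same time, so it cannot show which of the two matters; a plain ethyl group, a longer chain or a cyclohexyl ring on the same nitrogen would help to separate them. As far as these compounds go, it also remains open whether cyclopentyl gives a similar step on the core of compound 1, which carries the methoxy group, and whether an amine at the end of a chain in this place would raise or lower the number.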